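The compounds below may be only part of what the source reports. "The series", "measured", "known", "first", "only" and "open" are said of these compounds alone.

Among the compounds with values here, compound 2 `O=c1c2cccnc2sn1-c1ccc(Br)cc1` gives 4430 nM in an assay for inhibition of histone acetyltransferase KAT2B (Homo sapiens), read by fluorescence (on this read-out higher numbers stand for weaker inhibition and lower numbers for stronger inhibition), and stands lowest of the two numbers so far; its nearest neighbour, compound 1 `O=c1c2cc([N+](=O)[O-])cnc2sn1-c1ccc(Br)cc1`, gives 4910 nM, and the step of a 1.1-fold lower number from compound 1 to compound 2 (0.04 log units; within the scatter) lies within the scatter. Compound 3 `O=c1c2cccnc2sn1-c1ccccc1` differs from compound 2 by hydrogen in place of bromo on an aromatic carbon. Within the data shown here, no measured step touches this position; the only step known, from compound 1 to compound 2, changes a group on the core and is flat. Compound 3 is therefore expected to move little, a 1.2-fold higher number from compound 2 to compound 3 (0.09 log units; within the scatter). The estimate for compound 3 is 5500 nM, within 2500 nM to 12000 nM.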

Compound 3, half-maximal inhibitory concentration: 7850 nM
Estimate against measurement, compound 3: 1.4-fold (0.15 log units) below, and the stated range covers the measured number.
By their numbers in this assay, from the lowest: compounds 2, 1 and 3 (each within the scatter of the next).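

On the six-membered aromatic ring of carbon only, para to a large group, hydrogen in place of bromo gives a 1.8-fold higher number from compound 2 to compound 3 (0.25 log units; within the scatter) in this assay. This first step at this position stays within the scatter, so these data do not separate bromo from hydrogen here. No measured evidence bears on this step. As far as these compounds go, whether an amine, a carboxylic acid or a longer chain at this position would give a step beyond the scatter remains open.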